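The source may hold more compounds than are shown below. What is called first, only, known or untested is meant among the compounds shown, and "the series" means these compounds.

Compound 1 `Cc1cc(C)cc(S(=O)(=O)c2c(C(N)=O)[nH]c3ccc(Cl)cc23)c1` carries an unsubstituted carbamoyl group on the shared core. In an ADME assay on MT4 cells (Homo sapiens) for cytotoxicity, read by MTT assay, with a stated time of 5 days (a higher number here means that more compound is tolerated, a lower number that less compound is tolerated), compound 1 gives 13000 nM, the lowest of the two plain numbers shown. Compound 2 `Cc1cc(C)cc(S(=O)(=O)c2c(C(=O)NC3CNC3)[nH]c3ccc(Cl)cc23)c1`, with azetidin-3-yl in place of hydrogen on the amide-type nitrogen, gives 37300 nM in this assay, so that a 2.9-fold higher number from compound 1 to compound 2 (0.46 log units; beyond the scatter). Compound 3 `Cc1cc(C)cc(S(=O)(=O)c2c(C(=O)NC3CN(S(C)(=O)=O)C3)[nH]c3ccc(Cl)cc23)c1` reaches only a limit of this assay, > 252000 nM. Putting methylsulfonyl onto the amine nitrogen in the ring gave an at least 6.7-fold higher number from compound 2 to compound 3 (0.82 log units; beyond the scatter), and both changes together gave an at least 19-fold higher number from compound 1 to compound 3 (1.28 log units; beyond the scatter).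

Compound 4 `Cc1cc(C)cc(S(=O)(=O)c2c(C(=O)NS(C)(=O)=O)[nH]c3ccc(Cl)cc23)c1` differs from compound 1 by methylsulfonyl in place of hydrogen on an amide-type nitrogen. The nearest measured step is an at least 6.7-fold higher number from compound 2 to compound 3 (0.82 log units; beyond the scatter), the same group entering on a nitrogen, so a modest rise in this assay is expected. Compound 4 is therefore estimated at 40000 nM, within 15000 nM to 130000 nM, an expected step of a 3.1-fold higher number from compound 1 to compound 4 (0.49 log units; beyond the scatter).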

Compound 4, half-maximal cytotoxic concentration: 40200 nM
For compound 4 the middle estimate is 1.0-fold (0.00 log units) below the measured one; low and high end bracket the measured number.
By their numbers in this assay, from the lowest: compound 1; then compounds 2 and 4 (each within the scatter of the next). At a limit, above all of these: compound 3.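

In this assay, methylsulfonyl set directly on the amide-type nitrogen gives a 3.1-fold higher number from compound 1 to compound 4 (0.49 log units; beyond the scatter), so the azetidine ring is not needed for a rise at this position. Exchanging azetidin-3-yl for methylsulfonyl on this nitrogen gives a 1.1-fold higher number from compound 2 to compound 4 (0.03 log units; within the scatter), while exchanging 1-(methylsulfonyl)azetidin-3-yl for it gives an at least 6.2-fold lower number from compound 3 to compound 4 (0.79 log units; beyond the scatter), so the largest number comes only with both the ring and the methylsulfonyl group. Compound 3 stands at a limit, so that step has no fixed size: the limit of > 252000 nM in this assay, at which 1 of the 4 values shown sits.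

As far as these compounds go, whether acetyl or phenylsulfonyl on this nitrogen would match methylsulfonyl remains open. So does the effect of a longer chain between the amide-type nitrogen and the methylsulfonyl group.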